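A few compounds are considered here, and "the series" means these few. Any claim that something is new, unique, unknown or untested is made for them only; others in the source may bear on it.

Of the compounds shown here, two sharing one core have so far been measured in an ADME assay on a cell-free system (serum, Homo sapiens) for metabolic stability; on this read-out higher numbers stand for a longer-lived compound and lower numbers for a shorter-lived compound. Compound 1 `O=C(CCCO[N+](=O)[O-])Oc1ccccc1C(=O)O` gives 0.47 h, and compound 2 `O=C(CCO[N+](=O)[O-])Oc1ccccc1C(=O)O` gives 0.26 h. Among the compounds with values here, compound 2 sits at the short-lived end of the two numbers, but its only neighbour is compound 1, and the step of a 1.8-fold lower number from compound 1 to compound 2 (0.26 log units; within the scatter) means the two cannot really be told apart.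

Compound 3 `O=C(CCCCCO[N+](=O)[O-])Oc1ccccc1C(=O)O` has not yet been measured. It differs from compound 2 by 3-(nitrooxy)propyl in place of nitrooxy on a saturated chain carbon, two bonds along the chain from a carbonyl carbon. Within the data shown here, only one measured step bears on this change: the move from compound 1 to compound 2 also altered the length of the saturated chain between the carbonyl and the nitrooxy group, by a single carbon, and it gave a 1.8-fold lower number from compound 1 to compound 2 (0.26 log units; within the scatter). Compound 3 extends the chain in the opposite direction and by three carbons, so a number on the longer-lived side of compound 2 is expected, though whether it clears the scatter is uncertain. The step from compound 2 to compound 3 is therefore estimated at a 2.7-fold higher number from compound 2 to compound 3 (0.43 log units; beyond the scatter). For compound 3 the expected half-life is 0.7 h, within a range from 0.3 h to 1.6 h.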

Compound 3, half-life in the serum assay: 2.03 h
Compound 3: middle estimate off by 2.9-fold (0.46 log units), on the low side; the whole stated range lies below it.
By their numbers in the serum assay, from the lowest: compounds 2 and 1 (each within the scatter of the next); then compound 3.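

In the serum assay the chain length at this position now clearly matters, since 3-(nitrooxy)propyl in place of nitrooxy gives a 7.8-fold higher number from compound 2 to compound 3 (0.89 log units; beyond the scatter) and 2-(nitrooxy)ethyl in place of nitrooxy gives a 4.3-fold higher number from compound 1 to compound 3 (0.64 log units; beyond the scatter); both steps lie beyond the scatter, which the earlier single-carbon step did not. In a physicochemical assay for acid dissociation, compound 2 gives 3.69 and compound 3 gives 3.69, which is no change at the digits printed from compound 2 to compound 3 (within the scatter), so the large change in half-life comes with no change in this second read-out. Nothing available here accounts for the longer half-life of compound 3.

On these data alone, the three compounds show only that the longest of these chains stands apart from the two shorter ones, so it remains open whether a still longer chain would raise the half-life further, leave it level or lower it. As far as these compounds go, it is also open whether the effect depends on chain length alone or would hold if an amine or an ether oxygen replaced one of the saturated chain carbons.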